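Series notes: aryl swap at the chain carbon

A few compounds are considered here, and "the series" means these few. Any claim that something is new, unique, unknown or untested is made for them only; others in the source may bear on it.

Compound 1, `COc1cc(-c2cncc(N[C@@H](C)c3ccccc3)n2)ccc1O`, gives 10000 nM in a functional assay on PC-3 cells (Homo sapiens) for cytotoxicity, read by MTT assay, with a stated time of 72 h; a lower number here means a stronger inhibitor, a higher number a weaker inhibitor.
Compound 2, `CCCC(Nc1cncc(-c2ccc(O)c(OC)c2)n1)c1ccc(OC)cc1`, gives 3000 nM in this assay.

Of the two measured compounds, compound 2 holds the lower number; compound 1 sits higher by a gap that is beyond the usual scatter. Compound 3, `CCCC(Nc1cncc(-c2ccc(O)c(OC)c2)n1)c1cccc(Cl)c1`, is not yet measured. It differs from compound 2 in one place: 3-chlorophenyl in place of 4-methoxyphenyl on a saturated chain carbon bound to a nitrogen on an aromatic ring and a saturated chain carbon. For the measured compounds named here, no measured pair shows this change, so no step can be read from the data for it. The expectation is for a step of modest size at most, not clearly beyond the scatter, with a slight lean toward a lower number. The estimated step from compound 2 to compound 3 in this assay is a 1.2-fold lower number from compound 2 to compound 3 (0.08 log units; within the scatter). Compound 3 is expected to give 2500 nM in this assay, with a range from 800 nM to 8000 nM.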

Compound 3, half-maximal inhibitory concentration: 1000 nM
Estimate against measurement, compound 3: 2.5-fold (0.40 log units) above; the measured number falls inside the stated range.
By their numbers in this assay, from the lowest: compound 3; then compound 2; then compound 1.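

For the compounds shown here, the aryl group on the saturated chain carbon is the first place with a readable step: in this assay, 3-chlorophenyl in place of 4-methoxyphenyl gives a 3.0-fold lower number from compound 2 to compound 3 (0.48 log units; beyond the scatter). This shows that the number responds to the aryl group at this position, but the swap changes both the substituent and where it stands on the ring, and it also removes the hydrogen-bond acceptor counted on 4-methoxyphenyl, so this single pair cannot separate these changes. Nothing available explains the step.

Still open, on these data alone, is how 4-chlorophenyl or 3-methoxyphenyl would read at this carbon, as either group would help separate substituent identity from placement. Also open, as far as these compounds go, is whether a longer chain on the same carbon would move the number further.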